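The source may hold more compounds than are shown below. What is called first, only, known or untested is meant among the compounds shown, and "the series" means these compounds.

Series in a functional assay on PC-3 cells (Homo sapiens) for cytotoxicity, read by MTT assay, with a stated time of 72 h; a higher number here means a weaker inhibitor, a lower number a stronger inhibitor
compound 1 `O=C(N/N=C/c1ccc(F)cc1)Nc1cc2c(Nc3ccc(F)c(Cl)c3)ncnc2cc1O[C@H]1CCOC1` gives "not active" (no number reported)
compound 2 `O=C(N/N=C/c1cccc(Br)c1)Nc1cc2c(Nc3ccc(F)c(Cl)c3)ncnc2cc1O[C@H]1CCOC1` gives 15500 nM
compound 3 `O=C(N/N=C/c1cccc(Cl)c1Cl)Nc1cc2c(Nc3ccc(F)c(Cl)c3)ncnc2cc1O[C@H]1CCOC1` gives 27400 nM

Among the measured compounds shown here, compound 2 and compound 3 are the only two with a number in this assay and they lie within the scatter of each other, while compound 1 gives no number. Next in the series is compound 4 `COc1cc(/C=N/NC(=O)Nc2cc3c(Nc4ccc(F)c(Cl)c4)ncnc3cc2O[C@H]2CCOC2)cc(OC)c1OC`, which has 3,4,5-trimethoxyphenyl in place of 2,3-dichlorophenyl on a carbon with a double bond to nitrogen. The group remains one six-membered aromatic ring of carbon only, but hydrogen-bond acceptors now come in with it.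

For the measured compounds named here, only one measured step bears on this place, a 1.8-fold higher number from compound 2 to compound 3 (0.25 log units; within the scatter) and it stays within the scatter. That is a thin guide. Going by the values given here, no measured compound carries the 3,4,5-trimethoxyphenyl group, and compound 1, changed at the same place, gives no number.

No step beyond the scatter is therefore expected in either direction, and the expected step (a 1.4-fold lower number from compound 3 to compound 4 (0.14 log units; within the scatter)) is an estimate with a wide margin. For compound 4 the estimated value is 20000 nM with an expected range from 7000 nM to 55000 nM if a number is reported at all.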

Compound 4, half-maximal inhibitory concentration: 29600 nM
Estimate against measurement, compound 4: 1.5-fold (0.17 log units) below; low and high end bracket the measured number.
By their numbers in this assay, from the lowest: compounds 2, 3 and 4 (each within the scatter of the next).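

Swapping 2,3-dichlorophenyl for 3,4,5-trimethoxyphenyl on a carbon with a double bond to nitrogen gives, in this assay, (a 1.1-fold higher number from compound 3 to compound 4 (0.03 log units; within the scatter)), and the swap from 3-bromophenyl gives (a 1.9-fold higher number from compound 2 to compound 4 (0.28 log units; within the scatter)). Until now only halogen-bearing phenyl groups with numbers could be compared at this position, whereas the new group has no halogen, is larger by heavy-atom count and brings hydrogen-bond acceptors, yet its number stays within the scatter of both earlier values, so across compounds 2, 3 and 4 these differences in the group come with no readable step. Steps involving compound 1 cannot be read, as it has no number, and no evidence at hand bears on this result.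

On these data alone, all three numbers belong to compounds with a substituted phenyl group at this place, so it remains open whether a basic amine, a carboxylic acid or a saturated ring such as cyclohexyl would give a step beyond the scatter in either direction. Also open, as far as these compounds go, is what separates compound 1 from the three compounds with numbers, since its group differs only in the halogen-bearing phenyl at this same place.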